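Removing the anilide nitro group in a bis-benzylidene piperidinone series

The source may hold more compounds than are shown below. What is called first, only, known or untested is meant among the compounds shown, and "the series" means these compounds.

Measured in a functional assay on CCRF-CEM cells (Homo sapiens) for cytotoxicity; on this read-out higher numbers stand for weaker inhibition and lower numbers for stronger inhibition:
compound 1 `COc1ccc(NC(=O)/C=C/C(=O)N2C/C(=C\c3ccc([N+](=O)[O-])cc3)C(=O)/C(=C/c3ccc([N+](=O)[O-])cc3)C2)cc1`, 760 nM
compound 2 `O=C(/C=C/C(=O)N1C/C(=C\c2ccc([N+](=O)[O-])cc2)C(=O)/C(=C/c2ccc([N+](=O)[O-])cc2)C1)Nc1ccc([N+](=O)[O-])cc1`, 410 nM
compound 3 `Cc1ccc(NC(=O)/C=C/C(=O)N2C/C(=C\c3ccccc3)C(=O)/C(=C/c3ccccc3)C2)cc1`, 1100 nM

Among the compounds with values here, compound 2 gives the lowest number of the three, but compound 1 lies within the scatter of it, so the two cannot be separated; compound 3 lies beyond the scatter, on the higher side, and it also carries a different core, so no single-point step connects it to compound 2.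

Compound 4 `O=C(/C=C/C(=O)N1C/C(=C\c2ccc([N+](=O)[O-])cc2)C(=O)/C(=C/c2ccc([N+](=O)[O-])cc2)C1)Nc1ccccc1` differs from compound 2 in one place: hydrogen in place of nitro on an aromatic carbon. Within the data shown here, the only measured step on this aromatic carbon is a 1.9-fold lower number from compound 1 to compound 2 (0.27 log units; within the scatter), within the scatter. Among the measured compounds shown here, no measured pair removes the substituent there altogether, so the expectation rests on that one step and on compound 3, whose value 1100 nM belongs to a different core.

In this assay compound 4 is therefore expected to shift little from compound 2, a 1.6-fold higher number from compound 2 to compound 4 (0.20 log units; within the scatter), toward a somewhat higher number if anything. The estimate for compound 4 is 650 nM, with a range from 300 nM to 1500 nM.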

Compound 4, half-maximal inhibitory concentration: 370 nM
For compound 4 the middle estimate is 1.8-fold (0.24 log units) above the measured one; the range from low to high includes it.
By their numbers in this assay, from the lowest: compounds 4, 2, 1 and 3 (each within the scatter of the next, the first and the last beyond it).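

In this assay the substituent on this aromatic carbon can be removed altogether: hydrogen in place of nitro gives a 1.1-fold lower number from compound 2 to compound 4 (0.04 log units; within the scatter) and leaves the two compounds inseparable. Hydrogen in place of methoxy gives a 2.1-fold lower number from compound 1 to compound 4 (0.31 log units; beyond the scatter) and is the only step at this position that passes the scatter, though modestly, so on this core no substituent is needed there to keep the number at the level of compound 2. No accompanying measurement bears on why the position behaves this way.

Still open, as far as these compounds go, is how an amine, a carboxylic acid or a longer alkyl chain on this carbon would compare with hydrogen. Also open, from the compounds shown here alone, is whether removing the methyl group from compound 3 would have as little effect on its core.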